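Sulfamoylphenyl Position and Liver S9 Stability Across Two Cores

The compounds below may be only part of what the source reports. "The series", "measured", "known", "first", "only" and "open" are said of these compounds alone.

Measured so far in an ADME assay on S9 fraction from liver (Rattus norvegicus) for metabolic stability, read by LC-MS, using NADPH, with a stated time of 30 min; on this read-out lower numbers stand for a less stable compound and higher numbers for a more stable compound:
- compound 1 `CCCCCCCCc1ccc(OCC(=O)Cn2nnc(-c3ccc(S(=O)(=O)N(C)C)cc3)n2)cc1` gives 65%
- compound 2 `CCCCCCCCc1ccc(OCC(=O)Cn2nnc(-c3cccc(S(=O)(=O)N(C)C)c3)n2)cc1` gives 9%
- compound 3 `CCCCCCCCc1ccc(OCC(=O)Cn2nnnc2-c2ccc(S(=O)(=O)N(C)C)cc2)cc1` gives 40%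

The change 3-(dimethylsulfamoyl)phenyl in place of 4-(dimethylsulfamoyl)phenyl on an aromatic carbon produced a number 56 percentage points lower from compound 1 to compound 2 (beyond the scatter). Compound 3 is built on a differently joined core; the difference between the two cores is not broken down here. Compound 4 `CCCCCCCCc1ccc(OCC(=O)Cn2nnnc2-c2cccc(S(=O)(=O)N(C)C)c2)cc1` is still to be measured in this assay. It relates to compound 3 by 3-(dimethylsulfamoyl)phenyl in place of 4-(dimethylsulfamoyl)phenyl on an aromatic carbon, the same kind of change as from compound 1 to compound 2 but not the same: in compound 3 the place is next to the ring atom that bears a large group, whereas in compound 1 it is two ring bonds from the ring atom that bears a large group. For compound 4 the expected step is a number 32 percentage points lower from compound 3 to compound 4 (beyond the scatter), set beside a number 56 percentage points lower from compound 1 to compound 2 (beyond the scatter), which rests on that single earlier step and on compound 3 starting from 40%, leaving less room to fall. Compound 4 is therefore estimated at 8%, between 1% and 25%.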

Compound 4, percent of the compound remaining: 24%
Compound 4: the middle estimate sits 16 percentage points below what was measured; measured number inside the range.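

In this assay, 3-(dimethylsulfamoyl)phenyl in place of 4-(dimethylsulfamoyl)phenyl gives a number 16 percentage points lower from compound 3 to compound 4 (beyond the scatter), so the direction of the earlier step recurs. The size of the step does not carry over from one core to the other: the same change on two cores in this assay, a number 56 percentage points lower (beyond the scatter) from compound 1 to compound 2 and a number 16 percentage points lower (beyond the scatter) from compound 3 to compound 4, 40 percentage points apart, beyond the scatter of two such steps Two pairs do not show why the size differs, and they give no rule for what this change would do on any further core.

All four compounds carry the octyl chain and the dimethylsulfamoyl group. As far as these compounds go, whether the direction and the core-dependent size persist with a shorter chain in place of octyl, or with a carboxylic acid in place of the dimethylsulfamoyl group, stays open.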